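Trading a Nitro Group for an Amino Group

This account rests on a few compounds, and the source may have more. Where it says the series, first, only, none or still open, it means among the compounds named here.

Measured in a functional assay on DU-145 cells (Homo sapiens) for cytotoxicity, read by trypan blue exclusion, with a stated time of 96 h (on this read-out lower numbers stand for stronger inhibition and higher numbers for weaker inhibition), compound 3 (`COc1cc(OC)c(/C=C/S(=O)(=O)Cc2ccc(OC)c([N+](=O)[O-])c2)c(OC)c1`) stands at 2500 nM as the highest of three numbers, and its gaps to the other two lie beyond the scatter. In this assay compound 1 (`COc1ccc(/C=C/S(=O)(=O)Cc2ccc(OC)c(N)c2)c(OC)c1`) reads 500 nM and compound 2 (`COc1ccc(CS(=O)(=O)/C=C/c2c(OC)cccc2OC)cc1N`) reads 50 nM with an amino group in each, while compound 3 carries a nitro group and differs from them elsewhere too.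

Compound 4 (`COc1cc(OC)c(/C=C/S(=O)(=O)Cc2ccc(OC)c(N)c2)c(OC)c1`) differs from compound 3 by a single swap, amino in place of nitro on an aromatic carbon, ortho to a methoxy group. For the measured compounds named here, no measured pair shows this swap alone. The expectation rests on two amino-bearing relatives, compound 1 at 500 nM and compound 2 at 50 nM in this assay, and both sit lower than compound 3. A fall in the number, meaning stronger inhibition and beyond the scatter, is expected, with an estimated 42-fold lower number from compound 3 to compound 4 (1.62 log units; beyond the scatter) as the size of the step. The estimated value for compound 4 is 60 nM with an expected range from 10 nM to 350 nM on this reasoning.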

Compound 4, half-maximal inhibitory concentration: 4 nM
The estimate for compound 4 lay 15-fold (1.18 log units) above the measured number, outside the stated range (below it).
By their numbers in this assay, from the lowest: compound 4; then compound 2; then compound 1; then compound 3.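

Read alone in this assay for the first time, amino in place of nitro on this aromatic carbon, ortho to a methoxy group, gives a 630-fold lower number from compound 3 to compound 4 (2.80 log units; beyond the scatter) with nothing else changed. The amino group is not the whole story, since methoxy in place of hydrogen on an aromatic carbon, with the amino group already present, gives a 13-fold lower number from compound 2 to compound 4 (1.10 log units; beyond the scatter) and also a 130-fold lower number from compound 1 to compound 4 (2.10 log units; beyond the scatter) in two separate comparisons. So a single added methoxy group also moves the number well beyond the scatter, and no measurement offered here says why either change acts as it does.

The compounds shown leave open whether an amino group is specifically needed on this carbon, or whether a hydroxyl group, a methylamino group or an acetamide would read as low. They also leave open how a chloro group or an ethoxy group would compare with the added methoxy group.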